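The compounds below may be only part of what the source reports. "The series", "measured", "known", "first", "only" and "open" are said of these compounds alone.

Compound 2 `CCOC(=O)c1cn(C(c2ccccc2)c2cc3cc(Br)ccc3nc2OC)nn1` gives 2.01% in an ADME assay on SK-OV-3 cells (Homo sapiens) for cytotoxicity, read by sulforhodamine B assay, with a stated time of 48 h, tested at 10 uM (a higher number here means more inhibition at the concentration tested (going by the name of the read-out), a lower number less inhibition), the lowest of the three numbers shown, though its gaps to compound 1 `CCCCCCc1cn(C(c2ccccc2)c2cc3cc(Br)ccc3nc2OC)nn1`, which gives 7.17%, and to compound 3 `COc1nc2ccc(Br)cc2cc1C(c1ccccc1)n1cc(CCO)nn1`, which gives 8.46%, both lie within the scatter. Compound 4 `COc1nc2ccc(Br)cc2cc1C(c1ccccc1)n1cc(-c2ccccc2C(F)(F)F)nn1` differs from compound 2 in one place (2-(trifluoromethyl)phenyl in place of ethoxycarbonyl on an aromatic carbon). The measured steps that bear on this carbon are a number 5.2 percentage points lower from compound 1 to compound 2 (within the scatter) and a number 6.5 percentage points higher from compound 2 to compound 3 (within the scatter), both within the scatter, so the groups tried so far at this carbon have moved the number little. Among the measured compounds shown here, no aromatic group has yet been tried there, so only a step within the scatter is expected for a number 6 percentage points higher from compound 2 to compound 4 (within the scatter). Compound 4 is therefore estimated at 8%, with a range from 0% to 25%.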

Compound 4, a percentage reported as inhibition, at one concentration (the size of the read-out at that concentration, not a potency): 9.55%
Compound 4: middle estimate off by 1.6 percentage points, on the low side, within the range that was stated.
By their numbers in this assay, from the lowest: compounds 2, 1, 3 and 4 (each within the scatter of the next).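

In this assay, among the compounds shown here, the only group here with an aromatic ring at this carbon, 2-(trifluoromethyl)phenyl, stays within the scatter of all three others, with a number 7.5 percentage points higher from compound 2 to compound 4 (within the scatter) and a number 1.1 percentage points higher from compound 3 to compound 4 (within the scatter) and a number 2.4 percentage points higher from compound 1 to compound 4 (within the scatter) as its steps. Across hexyl, ethoxycarbonyl, 2-hydroxyethyl and this aryl group, no step at this position lies beyond the scatter. Nothing measured here accounts for how close these numbers lie. As far as these compounds go, it remains open whether an amine or a carboxylic acid at this carbon would give a step beyond the scatter. A pyridine ring in place of the phenyl ring is equally untested among the compounds shown.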